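A few compounds are considered here, and "the series" means these few. Any claim that something is new, unique, unknown or untested is made for them only; others in the source may bear on it.

Working notes on the series. In a functional assay on A-431 cells (Homo sapiens) for cytotoxicity, read by MTT assay, with a stated time of 72 h, tested at 30 uM (a higher number here means more inhibition of growth at the concentration tested, a lower number less inhibition of growth), compound 1 `N/C(=N\NC(=S)N1CCCC1)c1ccc(F)cn1` gives 83.3%, and compound 2 `Cc1cccc(/C(N)=N/NC(=S)N2CCSCC2)n1` gives 64.5%, the lower of the two numbers shown, with compound 1 standing higher than compound 2 by a gap beyond the usual scatter. Compound 3 `Cc1cccc(/C(N)=N/NC(=S)N2CCCCC2)n1` is not yet measured; it differs from compound 2 by piperidin-1-yl in place of thiomorpholin-4-yl on a thiocarbonyl carbon. For the measured compounds named here, no measured pair isolates this change, so the step is expected to be small, at most a modest rise, and may well lie within the scatter. For compound 3 the estimate in this assay is 68%, within 50% to 85%, which is expected to mean a step of a number 3.5 percentage points higher from compound 2 to compound 3 (within the scatter).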

Compound 3, percent growth inhibition at one concentration: 65.2%
Estimate against measurement, compound 3: 2.8 percentage points above; the range from low to high includes it.
By their numbers in this assay, from the lowest: compounds 2 and 3 (each within the scatter of the next); then compound 1.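

In this assay, for the compounds shown here, piperidin-1-yl in place of thiomorpholin-4-yl on a thiocarbonyl carbon gives a number 0.7 percentage points higher from compound 2 to compound 3 (within the scatter) and is the first matched pair at this position. On this core, the sulfur of the thiomorpholin-4-yl ring is therefore not required for growth inhibition at this level. Nothing available explains this result.

Going by these compounds alone, compound 1 differs from compound 3 in more than one place, so no step to it can be read. On these data alone, whether morpholin-4-yl or an open-chain dimethylamino group in this place would read alike remains open.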